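Sulfonamide piperidine carboxamides: a proposed amide change

The source may report more compounds than this note shows. Statements on the series, on what has been measured and on what is new or still open speak of the compounds shown alone.

Compound 1: `O=C([C@@H]1CCCN(S(=O)(=O)c2ccc(S(=O)(=O)C3CCC3)cc2)C1)N1CCC(F)(F)CC1` — > 3000 nM
Compound 2: `CCN(CC)S(=O)(=O)c1ccc(S(=O)(=O)N2CCC[C@@H](C(=O)N3CCS(=O)(=O)CC3)C2)cc1` — > 10000 nM
Compound 3: `O=C([C@@H]1CCCN(S(=O)(=O)c2ccc(S(=O)(=O)N3CC[C@@H](O)C3)cc2)C1)N1CCC(F)(F)CC1` — > 3000 nM

Of the compounds shown here, three share a core and have been tested in a functional assay on MIA PaCa-2 cells (Homo sapiens) for inhibition, read by MTT assay, with a stated time of 3 days; a lower number here means a stronger inhibitor, a higher number a weaker inhibitor. For compound 1 the result is only a limit, > 3000 nM. For compound 3 the result is likewise only a limit, > 3000 nM. The step that the two limits leave unreadable from compound 1 to compound 3 cannot therefore be read. For compound 2 the result is again a limit, > 10000 nM, the most generous of the three in the sense that it is the limit of > 10000 nM in this assay, at which 1 of the 3 values shown sits, while the other two values sit at the limit of > 3000 nM in this assay, at which 2 of the 3 values shown sit. Compound 2 thus stands at a limit, with no number behind it.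

Compound 4 is `CCN(CC)S(=O)(=O)c1ccc(S(=O)(=O)N2CCC[C@@H](C(=O)N[C@H]3CC[C@H](OC)CC3)C2)cc1`. Its difference from compound 2 is (4-methoxycyclohexyl)amino in place of 1,1-dioxothiomorpholin-4-yl on a carbonyl carbon. For the measured compounds named here, no measured step bears on this change: the one step available, a step that the two limits leave unreadable from compound 1 to compound 3, concerns a different position and is unreadable. For compound 4 the expected result is therefore again a limit rather than a number, with an estimated step that the limit leaves unreadable from compound 2 to compound 4 of no readable size. The estimate for compound 4 is 12000 nM, between 2500 nM and 60000 nM.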

Compound 4, half-maximal inhibitory concentration: > 10000 nM
Compound 4 was reported as a limit; the forecaster's own chance of this, stated with the estimate: 75%; the middle value does not contradict the limit.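

Compound 4 gives > 10000 nM, which is a limit. Compound 2 also gives a limit, > 10000 nM, and the step from compound 2 to compound 4 cannot be read. The compounds shown leave open what potency, if any, the shared core can reach in this assay.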